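A second chlorine on a compound at the limit

A few compounds are considered here, and "the series" means these few. Any claim that something is new, unique, unknown or untested is made for them only; others in the source may bear on it.

Measured in a functional assay on HepG2 cells (Homo sapiens) for cytotoxicity, read by MTT assay, with a stated time of 72 h; on this read-out lower numbers stand for stronger inhibition and higher numbers for weaker inhibition:
compound 1 `CNC(=O)c1cc(Oc2ccc(C3=NN(C(N)=S)C(c4cccc([N+](=O)[O-])c4)C3)cc2)ccn1` gives > 50000 nM as a limit
compound 2 `CNC(=O)c1cc(Oc2ccc(C3=NN(C(N)=S)C(c4ccc(Cl)cc4)C3)cc2)ccn1` gives > 50000 nM as a limit

Among the compounds with values here, compound 2 gives > 50000 nM as its only reading, and this is a limit rather than a number. Compound 3 `CNC(=O)c1cc(Oc2ccc(C3=NN(C(N)=S)C(c4cccc(Cl)c4Cl)C3)cc2)ccn1` differs from compound 2 in one place 2,3-dichlorophenyl in place of 4-chlorophenyl on a saturated ring carbon with 2,3-dichlorophenyl in place of 4-chlorophenyl on a saturated ring carbon. Within the data shown here, one measured step bears on this change, a step that the two limits leave unreadable from compound 1 to compound 2 and it too alters the group on that carbon. Its size cannot be read, and both values are limits, as the limit of > 50000 nM in this assay, at which 2 of the 2 values shown sit, shows. Among the measured compounds shown here, no measured step therefore points to a change in either direction, and another limit is the likeliest reading. The expected step is a number no higher from compound 2 to compound 3 (the limit leaves the size open) and it is only an estimate. For compound 3 the estimated value is 50000 nM with an expected range from 20000 nM to 100000 nM in this assay.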

Compound 3, half-maximal inhibitory concentration: 1890 nM
Estimate against measurement, compound 3: 26-fold (1.42 log units) above, outside the stated range (below it).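

In this assay, the group on the saturated ring carbon proves able to move the read-out, which the earlier pair could not show, with an at least 26-fold lower number from compound 2 to compound 3 (1.42 log units; beyond the scatter) and an at least 26-fold lower number from compound 1 to compound 3 (1.42 log units; beyond the scatter). Both steps start from a limit, so each gives only a minimum size, and the 2,3-dichlorophenyl group is the only one of the three groups shown at this carbon that gives a number. The 4-chlorophenyl and 3-nitrophenyl groups remain at the limit: the limit of > 50000 nM in this assay, at which 2 of the 3 values shown sit.

The step from the 4-chlorophenyl group to the 2,3-dichlorophenyl group changes both the number of chlorines and where they sit on the ring, and the compounds shown do not separate these two changes. They also leave open whether a single chlorine on a 2-chlorophenyl or 3-chlorophenyl group, or a 2,3-dimethylphenyl group with its two methyl groups, would give a number at this carbon.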